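The compounds below may be only part of what the source reports. "The series", "measured", "known", "first", "only" and "open" are said of these compounds alone.

Among the compounds with values here, compound 1 `Cc1cc(OC(=O)C(C)(C)CCC(CO[N+](=O)[O-])O[N+](=O)[O-])n(-c2ccccc2)n1` carries the only number so far. In an ADME assay on a cell-free system (serum, Homo sapiens) for metabolic stability, read by HPLC, tested at 250 uM (on this read-out higher numbers stand for a longer-lived compound and lower numbers for a shorter-lived compound), compound 1 gives 0.27 h and so stands alone as the one measured point. Compound 2 `Cc1cc(OC(=O)OCCCCC(CO[N+](=O)[O-])O[N+](=O)[O-])n(-c2ccccc2)n1` is recorded only as < 0.0167 h in this assay, which is a limit of the read-out and not a number. Compound 3 `Cc1cc(OC(=O)C(C)(C)CCCCO[N+](=O)[O-])n(-c2ccccc2)n1` differs from compound 1 in one place: hydrogen in place of nitrooxy on a saturated chain carbon bound to two saturated chain carbons. Within the data shown here, with no measured step in the set, the expected step of a 1.3-fold higher number from compound 1 to compound 3 (0.11 log units; within the scatter) in this assay is taken as none beyond the usual scatter. Compound 3 is therefore estimated at 0.35 h in this assay, with a range from 0.15 h to 0.8 h.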

Compound 3, half-life in the serum assay: 0.222 h
Compound 3: the middle estimate sits 1.6-fold (0.20 log units) above what was measured, and the stated range covers the measured number.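

In the serum assay there is a 1.2-fold lower number from compound 1 to compound 3 (0.09 log units; within the scatter) so taking one nitrooxy off the saturated chain carbon bound to two saturated chain carbons does not register in this read-out. In a physicochemical assay for metabolic stability, read by HPLC (on this read-out higher numbers stand for a longer-lived compound and lower numbers for a shorter-lived compound), compound 1 gives 10 h and compound 3 gives 24 h with a 2.4-fold higher number from compound 1 to compound 3 (0.38 log units; beyond the scatter) so the same change registers only in this second read-out. Still open, from the compounds shown here alone, is how the serum assay and the physicochemical assay respond to an amine or a carboxylic acid in place of the nitrooxy at this position. A longer chain carrying the remaining nitrooxy also stays untested in the compounds shown.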